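Nitro in place of amino: two cores, one change

A few compounds are considered here, and "the series" means these few. Any claim that something is new, unique, unknown or untested is made for them only; others in the source may bear on it.

Measured so far:
- Compound 1 `COc1ccc(/C=C(/F)c2cc(OC)c(OC)c(OC)c2)cc1N`: 2.4 nM in a functional assay on NCI-H460 cells (Homo sapiens) for cytotoxicity, read by sulforhodamine B assay, with a stated time of 72 h; a higher number here means a weaker inhibitor, a lower number a stronger inhibitor
- Compound 3 `COc1ccc(/C(F)=C\c2cc(OC)c(OC)c(OC)c2)cc1N`: 11.5 nM in this assay
- Compound 2 `COc1ccc(/C(F)=C\c2cc(OC)c(OC)c(OC)c2)cc1[N+](=O)[O-]`: 379 nM in this assay

Compound 1 and compound 3 share the same atoms joined differently; the difference between the two cores is not broken down here. Compound 1 stands lowest of the three, with compound 3 the nearest.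

From compound 3 to compound 2 the change is nitro in place of amino on an aromatic carbon, and in this assay it gave a 33-fold higher number from compound 3 to compound 2 (1.52 log units; beyond the scatter).

Compound 4 `COc1ccc(/C=C(/F)c2cc(OC)c(OC)c(OC)c2)cc1[N+](=O)[O-]` is not yet measured. It arises from compound 1 by nitro in place of amino on an aromatic carbon, the same change as from compound 3 to compound 2, on the same place. The step is expected to be of like size, a 33-fold higher number from compound 1 to compound 4 (1.52 log units; beyond the scatter), resting on compound 3 to compound 2 with a 33-fold higher number from compound 3 to compound 2 (1.52 log units; beyond the scatter). Compound 4 is therefore estimated at 80 nM, between 20 nM and 320 nM.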

Compound 4, half-maximal inhibitory concentration: 42.6 nM
Beside the measured number, compound 4's estimate is 1.9-fold (0.27 log units) above it; measured number inside the range.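

In this assay, nitro in place of amino on the core of compound 1 gave an 18-fold higher number from compound 1 to compound 4 (1.25 log units; beyond the scatter), and the change carries across the two cores with no difference in size beyond the scatter: the same change on two cores in this assay, a 33-fold higher number (1.52 log units; beyond the scatter) from compound 3 to compound 2 and an 18-fold higher number (1.25 log units; beyond the scatter) from compound 1 to compound 4, 1.9-fold (0.27 log units) apart, within the scatter of two such steps. Both steps run the same way, with the amino compound at the lower number on each core. This rests on two pairs, one assay and one place on the ring, so it does not show that the step would hold on any other core, nor why the number rises.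

Still open, on these data alone, is whether other groups at this place, such as a hydroxyl, an acetamide or a dimethylamino group, would fall nearer the amino or the nitro compounds. Also open, as far as these compounds go, is whether the step keeps its size outside this assay.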